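A few compounds are considered here, and "the series" means these few. Any claim that something is new, unique, unknown or untested is made for them only; others in the source may bear on it.

Measured set in an assay on CHO cells for displacement of a labelled ligand from adenosine receptor A1 (Homo sapiens), read by scintillation counting, tested at 1 uM; on this read-out higher numbers stand for more inhibition at the one concentration tested (going by the name of the read-out) and lower numbers for less inhibition:
compound 1, `CC(C)Cc1nc(N)c2nn(-c3ccccc3)cc2n1`: 49%
compound 2, `CC(C)c1nc(N)c2nn(-c3ccccc3)cc2n1`: 2%
compound 3, `Nc1nc(Cc2cccc(Cl)c2)nc2cn(-c3ccccc3)nc12`: 32%

Compound 1 stands highest of the three numbers. Compound 3 is nearest, with a number 17 percentage points lower from compound 1 to compound 3 (beyond the scatter), and compound 2 is furthest, with a number 47 percentage points lower from compound 1 to compound 2 (beyond the scatter). The next member, compound 4 `Nc1nc(CCc2ccccc2)nc2cn(-c3ccccc3)nc12`, keeps the core of compound 1 and differs from it in one place: benzyl in place of isopropyl on a saturated chain carbon bound to an aromatic carbon.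

The measured step that bears on this most directly is a number 17 percentage points lower from compound 1 to compound 3 (beyond the scatter), where an aromatic ring likewise replaces isopropyl on the saturated chain carbon; that step was modest. The step of a number 30 percentage points higher from compound 2 to compound 3 (beyond the scatter) also involves an aryl-bearing group, but it starts from a different compound and so only shows that such a group can sit at that place with a number well above compound 2. Among the compounds with values here, compound 3 carries a chlorine on its ring while compound 4 does not, and no measured pair shows what that difference alone does, so the range must stay wide.

On this basis a modest fall from compound 1 is expected for compound 4, a number 16 percentage points lower from compound 1 to compound 4 (beyond the scatter). Compound 4 is therefore estimated at 33% in this assay, within 15% to 50%.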

Compound 4, a percentage reported as inhibition, at one concentration (the size of the read-out at that concentration, not a potency): 15%
Compound 4: the middle estimate sits 18 percentage points above what was measured; low and high end bracket the measured number.
By their numbers in this assay, from the lowest: compound 2; then compound 4; then compound 3; then compound 1.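

Changing isobutyl to phenethyl on the aromatic carbon gives a large fall (a number 34 percentage points lower from compound 1 to compound 4 (beyond the scatter)), so an aryl-bearing group at this place does not by itself keep the number close to that of the isobutyl compound. The phenethyl compound also falls short of the 3-chlorobenzyl compound (a number 17 percentage points lower from compound 3 to compound 4 (beyond the scatter)), yet it still reads above the isopropyl compound (a number 13 percentage points higher from compound 2 to compound 4 (beyond the scatter)), which places phenethyl between the other groups in this small set. No measured evidence on the cause of these differences is available.

The compounds shown do not separate the effect of the chlorine from that of the group's shape, since 3-chlorobenzyl and phenethyl differ in both. As far as these compounds go, how a plain benzyl group, a longer alkyl chain or a chain ending in an amine or carboxylic acid would read at this place remains open.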